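The source may hold more compounds than are shown below. What is called first, only, known or untested is meant among the compounds shown, and "the series" means these compounds.

Measured so far in the series:

compound 1 `CSc1[nH]ccc2ncnc1-2`: < 5%
compound 2 `OC[C@H]1OC(n2cnc3c(SCc4ccccc4)nccc32)[C@H](O)[C@@H]1O`: 30%
compound 3 `[N-]=[N+]=Nc1nccc2c1ncn2[C@H]1C[C@H](O)[C@@H](CO)O1`: 13%

All three were run in a functional assay on EL4 cells (Mus musculus) for inhibition, tested at 100 uM; on this read-out lower numbers stand for less inhibition and higher numbers for more inhibition at the one concentration tested (going by the name of the read-out). The value of compound 1 in this assay is a limit of the assay, not a number; it sits at the limit of < 5% in this assay, at which 1 of the 3 values shown sits. Of the two numbers that remain, compound 2 stands highest. Compound 3, the nearest to it, gives 13% in this assay, a gap from compound 2 that lies beyond the usual scatter of repeated measurements. No pair among these three differs in only one place, so no single measured step can be followed.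

The next compound to be measured is compound 4 `CNc1nccc2c1ncn2C1O[C@H](CO)[C@@H](O)[C@H]1O`. It is compared with compound 2, from which it differs as follows: methylamino in place of benzylsulfanyl on an aromatic carbon.

Among the measured compounds shown here, for this step in this assay, the expectation is a move downward beyond the scatter, since the one compound carrying a small group in this position, compound 1, gives < 5%. The expected step is a number 18 percentage points lower from compound 2 to compound 4 (beyond the scatter). Compound 4 is estimated to give 12% in this assay, within a range from 3% to 25%.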

Compound 4, a percentage reported as inhibition, at one concentration (the size of the read-out at that concentration, not a potency): 11%
For compound 4 the middle estimate is 1 percentage points above the measured one; the measured number falls inside the stated range.
By their numbers in this assay, from the lowest: compounds 4 and 3 (each within the scatter of the next); then compound 2. At a limit, below all of these: compound 1.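

In this assay, the exchange of benzylsulfanyl for methylamino on the aromatic carbon next to the ring nitrogen gives a number 19 percentage points lower from compound 2 to compound 4 (beyond the scatter). Among the compounds shown here, this is the first single change that can be followed at this position, and it shows that the substituent there matters to inhibition at the one concentration tested, with the rest of compound 2 unchanged. The exchange removes the carbon-only aromatic ring and the sulfur together and brings in nitrogen, so this one step does not separate these changes from one another. Compound 1, which has a small group at this position on a different scaffold, remains a limit of the assay and not a number, and gives no step to set beside this one: the limit of < 5% in this assay, at which 1 of the 4 values shown sits.

As far as these compounds go, it remains open whether the loss follows the aromatic ring or the atom joining the group to the core. Benzylamino or methylsulfanyl on this carbon of compound 2 would separate the two, and a longer chain such as butylamino would show whether a ring is needed at all.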